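The compounds below may be only part of what the source reports. "The series", "measured", "known", "first", "only" and "open" are said of these compounds alone.

Among the measured compounds shown here, compound 3, `COc1ccc(-n2nc(C(=O)Nc3ccccc3C)nc2-c2cc(OC)c(OC)c(OC)c2)cc1`, stands lowest of the three numbers so far. In a functional assay on the whole organism for inhibition, with Rattus norvegicus as the target, read by paw edema, with stated times of 30 min and 2 h, at a dose of 0.28 mmol/kg by the oral route (a lower number here means less inhibition, a higher number more inhibition at the dose given (going by the name of the read-out)), compound 3 gives 30%. Its nearest neighbour on the numbers is compound 2, `COc1ccc(-n2nc(C(=O)Nc3ccc(C)cc3)nc2-c2cc(OC)c(OC)c(OC)c2)cc1`, which in this assay gives 60%; the furthest is compound 1, `CCNC(=O)c1nc(-c2cc(OC)c(OC)c(OC)c2)n(-c2ccc(OC)cc2)n1`, which gives 68%. Both gaps are beyond the scatter: a number 30 percentage points lower from compound 2 to compound 3 (beyond the scatter) and a number 38 percentage points lower from compound 1 to compound 3 (beyond the scatter).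

Compound 4 is `COc1ccc(-n2nc(C(=O)Nc3ccc(O)cc3)nc2-c2cc(OC)c(OC)c(OC)c2)cc1`. It differs from compound 3 in one place: 4-hydroxyphenyl in place of 2-methylphenyl on an amide-type nitrogen.

For the measured compounds named here, two measured steps bear on this change. The step from compound 2 to compound 3 shows what a 2-methylphenyl does against a 4-methylphenyl on the same amide-type nitrogen: a number 30 percentage points lower from compound 2 to compound 3 (beyond the scatter). The step from compound 1 to compound 3 shows the same 2-methylphenyl against ethyl: a number 38 percentage points lower from compound 1 to compound 3 (beyond the scatter). Going by the values given here, compound 4 removes the 2-methylphenyl and carries a 4-hydroxyphenyl, a group that has no measured counterpart here; the closest comparison is compound 2 with its 4-methylphenyl. The expectation is therefore a step upward from compound 3, beyond the scatter, of about the size seen between compound 2 and compound 3, so that compound 4 is expected to come back near compound 2: a number 25 percentage points higher from compound 3 to compound 4 (beyond the scatter). Compound 4 is thus estimated at 55%, with a range from 35% to 72%.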

Compound 4, a percentage reported as inhibition, in the whole organism at one dose (the size of the read-out at that dose, not a potency): 35%
Compound 4: the middle estimate sits 20 percentage points above what was measured; the measured number falls inside the stated range.
By their numbers in this assay, from the lowest: compounds 3 and 4 (each within the scatter of the next); then compounds 2 and 1 (each within the scatter of the next).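

In this assay, the 4-hydroxyphenyl and the 2-methylphenyl on the amide-type nitrogen cannot be told apart, with a number 5 percentage points higher from compound 3 to compound 4 (within the scatter), so a low number on this nitrogen is no longer tied to the 2-methylphenyl alone. The earlier compounds shown here also gave no sign that a single change on the aromatic ring could matter while the 4 position stayed occupied, yet hydroxy in place of methyl on an aromatic carbon gives a number 25 percentage points lower from compound 2 to compound 4 (beyond the scatter), and the 4-hydroxyphenyl set against ethyl gives a number 33 percentage points lower from compound 1 to compound 4 (beyond the scatter), leaving ethyl and 4-methylphenyl as the two groups with the higher numbers. No evidence in hand gives a cause for these steps.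

The compounds shown leave open whether an amine or a fluorine in place of the hydroxy would read with compound 2 or with compound 4, and whether a carboxylic acid on that aromatic carbon would follow either one. They also leave open how a 2-hydroxyphenyl or a propyl chain on the same amide-type nitrogen would read.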